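From compound 3 to compound 4: cytotoxicity notes

The compounds below may be only part of what the source reports. "The series", "measured", "known", "first", "only" and "open" are said of these compounds alone.

In a functional assay on cells (Homo sapiens) for cytotoxicity, read by MTT assay, with a stated time of 24 h (a higher number here means a weaker inhibitor, a lower number a stronger inhibitor), compound 3 (`CCCCCCCCCCCCCCNC(=O)[C@H](CO)NCc1ccccc1OC`) gives 100000 nM, the highest number of the three measured. Compound 1 (`CCCCCCCCCCCCCCNC(=O)[C@H](CO)/N=C/c1ccccc1Cl`) gives 10300 nM, and compound 2 (`CCCCCCCCCCCCCCNC(=O)[C@H](CO)/N=C/c1ccc(Cl)cc1`) gives 27500 nM. Compound 4 (`CCCCCCCCCCCCCCNC(=O)[C@H](CO)/N=C/c1cccc(O)c1`), not yet measured, differs from compound 3 thus: a group of 9 heavy atoms (7 carbon, 1 nitrogen, 1 oxygen; one six-membered aromatic ring of carbon only) in place of a group of 10 heavy atoms (8 carbon, 1 nitrogen, 1 oxygen; one six-membered aromatic ring of carbon only), on a saturated chain carbon bound to a carbonyl carbon and a saturated chain carbon. Compound 1 and compound 2 also carry the double bond outside aromatic rings, so the closest guides are a 9.7-fold higher number from compound 1 to compound 3 (0.99 log units; beyond the scatter) and a 3.6-fold higher number from compound 2 to compound 3 (0.56 log units; beyond the scatter), here read in reverse. Among the compounds with values here, the ring matters too, as a 2.7-fold higher number from compound 1 to compound 2 (0.43 log units; beyond the scatter) shows, and no measured compound has the ring of compound 4. A move to a lower number is expected, with an estimated size of a 4.0-fold lower number from compound 3 to compound 4 (0.60 log units; beyond the scatter). For compound 4 the estimated value is 25000 nM, with an expected range of 8000 nM to 70000 nM.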

Compound 4, half-maximal inhibitory concentration: 32600 nM
The estimate for compound 4 lay 1.3-fold (0.12 log units) below the measured number; the measured number falls inside the stated range.
By their numbers in this assay, from the lowest: compound 1; then compounds 2 and 4 (each within the scatter of the next); then compound 3.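

In this assay, the step to the double bond outside aromatic rings with a 3-hydroxyphenyl group (a 3.1-fold lower number from compound 3 to compound 4 (0.49 log units; beyond the scatter)) shows that a lower number than compound 3 does not require a chlorine on the ring. On the carbon with a double bond to nitrogen, 3-hydroxyphenyl and 4-chlorophenyl are not separated (a 1.2-fold higher number from compound 2 to compound 4 (0.07 log units; within the scatter)), while 2-chlorophenyl remains distinct (a 3.2-fold higher number from compound 1 to compound 4 (0.50 log units; beyond the scatter)). Nothing available accounts for these differences.

Still open, on these data alone, is how 3-hydroxyphenyl behaves with the saturated link of compound 3. Also open, as far as these compounds go, is the effect of a carboxylic acid or an amine in place of the hydroxyl, or of a longer chain on the amide.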